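Removing a Fluorine From an Inactive Ketoamide

The compounds below may be only part of what the source reports. "The series", "measured", "known", "first", "only" and "open" are said of these compounds alone.

compound 1 `CCOC(=O)C(F)(F)C(O)CCc1ccccc1` — in an assay on HEK-293T cells for inhibition of phospholipase A and acyltransferase 2 (Homo sapiens), with stated times of 30 min and 20 min (a higher number here means a weaker inhibitor, a lower number a stronger inhibitor), compound 1 gives > 10000 nM, a limit of the assay and not a number.
compound 2 `O=C(CCc1ccccc1)[C@H](F)C(=O)NCc1ccccc1` — in this assay compound 2 gives > 10000 nM, likewise a limit.

Compound 2 therefore stands at no numbered position: only a limit is known for it, and the same holds for the other measured compound, as the limit of > 10000 nM in this assay, at which 2 of the 2 values shown sit, shows. Compound 3 `O=C(CCc1ccccc1)CC(=O)NCc1ccccc1` differs from compound 2 by hydrogen in place of fluoro on a saturated chain carbon bound to two carbonyl carbons. Going by the values given here, no measured pair shows what such a change does here, so the expectation rests only on where compound 2 stands. The step from compound 2 to compound 3 in this assay is expected to be a step that the limit leaves unreadable from compound 2 to compound 3, nothing beyond the scatter. Compound 3 is thus estimated at 20000 nM, within 5000 nM to 100000 nM, most likely again reported only as a limit.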

Compound 3, half-maximal inhibitory concentration: > 10000 nM
Compound 3 was reported as a limit; the forecaster's own chance of this, stated with the estimate: 80%; the middle value lies beyond the limit too.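

No step can be read from compound 2 to compound 3, as both stand only at a limit of the assay: the limit of > 10000 nM in this assay, at which 3 of the 3 values shown sit.

The compounds shown leave open whether swapping fluoro for hydrogen changes inhibition in this assay at all.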